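Two Sulfonamides Measured, a Third Awaits Its Number

The source may report more compounds than this note shows. Statements on the series, on what has been measured and on what is new or still open speak of the compounds shown alone.

compound 1 `O=S(=O)(Nc1ccc(-c2nc3cc(NS(=O)(=O)c4ccc(Cl)s4)ccc3o2)cc1)c1cccc(C(F)(F)F)c1`: in an assay for inhibition of HSP60/HSP10 (Homo sapiens), with a stated time of 60 min (a lower number here means a stronger inhibitor, a higher number a weaker inhibitor), compound 1 gives 4500 nM
compound 2 `O=[N+]([O-])c1cc(S(=O)(=O)Nc2ccc3oc(-c4ccc(NS(=O)(=O)c5ccc(Cl)s5)cc4)nc3c2)ccc1Cl`: in this assay compound 2 gives 1000 nM

Within the data shown here, compound 2 holds the lower of the two numbers measured so far, and its gap to compound 1 lies beyond the usual scatter of repeated measurements. Compound 3 `O=S(=O)(Nc1ccc(-c2nc3cc(NS(=O)(=O)c4ccc(Cl)s4)ccc3o2)cc1)c1ccc(Cl)s1` differs from compound 2 in a single place: 5-chlorothiophen-2-yl in place of 4-chloro-3-nitrophenyl on a sulfonyl sulfur. The group that enters is the same one already carried on the other sulfonamide of the shared core, so compound 3 bears two identical sulfonyl substituents. Among the measured compounds shown here, no measured pair shows this exchange, so the expectation rests on the two values alone. A step toward a higher number in this assay is expected, of the size a 2.0-fold higher number from compound 2 to compound 3 (0.30 log units; within the scatter), and it may well fall within the scatter. Compound 3 is therefore estimated at 2000 nM, with a plausible range from 600 nM to 7000 nM.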

Compound 3, half-maximal inhibitory concentration: 5900 nM
The estimate for compound 3 lay 3.0-fold (0.47 log units) below the measured number; low and high end bracket the measured number.
By their numbers in this assay, from the lowest: compound 2; then compounds 1 and 3 (each within the scatter of the next).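

In this assay, the exchange on the sulfonyl sulfur now has a measured size: 5-chlorothiophen-2-yl in place of 4-chloro-3-nitrophenyl gives a 5.9-fold higher number from compound 2 to compound 3 (0.77 log units; beyond the scatter), a clear loss of inhibition. Set against 3-(trifluoromethyl)phenyl at the same place, the same group gives a 1.3-fold higher number from compound 1 to compound 3 (0.12 log units; within the scatter), so compound 2 alone stands apart among the three. Compound 1 also carries a six-membered aromatic ring of carbon only, yet it lies within the scatter of compound 3, so ring type alone does not set the number. Nothing given here bears on the reason for these differences.

The compounds shown do not separate the nitro group from the chlorine of 4-chloro-3-nitrophenyl. Going by these compounds, how an amine or a carboxylic acid on this sulfonyl sulfur would read also remains open.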